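Nitro on the Aryl Hydrazone of Compound 1

The source may hold more compounds than are shown below. What is called first, only, known or untested is meant among the compounds shown, and "the series" means these compounds.

Measured so far in an assay on isolated protein for inhibition of Amine oxidase [flavin-containing] A (Homo sapiens), read by spectrophotometry; a higher number here means a weaker inhibitor, a lower number a stronger inhibitor:
Compound 1 `C(=N/Nc1nc2ccccc2nc1Cc1ccccc1)\c1ccccc1`: compound 1 gives 81 nM
Compound 2 `C/C(=N\Nc1nc2ccccc2nc1Cc1ccccc1)c1ccccn1`: compound 2 gives 91 nM
Compound 3 `C/C(=N\Nc1nc2ccccc2nc1Cc1ccccc1)c1cccs1`: compound 3 gives 64 nM

Compound 1 stands second highest of the three numbers; its nearest neighbour is compound 2 and its furthest is compound 3, and all three values sit within the scatter of one another, so no order among them can be read. The steps that are known change the aryl ring on the carbon with a double bond to nitrogen: a 1.1-fold higher number from compound 1 to compound 2 (0.05 log units; within the scatter), a 1.3-fold lower number from compound 1 to compound 3 (0.10 log units; within the scatter) and a 1.4-fold lower number from compound 2 to compound 3 (0.15 log units; within the scatter), each within the scatter.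

Compound 4 `O=[N+]([O-])c1ccc(/C=N/Nc2nc3ccccc3nc2Cc2ccccc2)cc1` differs from compound 1 in that (nitro in place of hydrogen on an aromatic carbon). Within the data shown here, none of the measured steps alters a substituent on a retained phenyl ring, so no step bears directly on this change; the nearest comparison is that swapping whole aryl rings left this assay essentially unchanged. Compound 4 is therefore expected to show no step beyond the scatter, a 1.2-fold lower number from compound 1 to compound 4 (0.06 log units; within the scatter), in this assay. Compound 4 is estimated at 70 nM, with a range from 25 nM to 200 nM.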

Compound 4, half-maximal inhibitory concentration: 8.8 nM
Estimate against measurement, compound 4: 8.0-fold (0.90 log units) above, and the stated range ends above it.
By their numbers in this assay, from the lowest: compound 4; then compounds 3, 1 and 2 (each within the scatter of the next).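

In this assay, among these compounds, the change from phenyl to 4-nitrophenyl gives a clear gain (a 9.2-fold lower number from compound 1 to compound 4 (0.96 log units; beyond the scatter)), the first step in this set to lie beyond the scatter. The earlier steps shown here exchanged one whole aryl ring for another and left the number within the scatter, whereas this one keeps the phenyl ring and places a nitro group on an aromatic carbon, para to a large group. This shows that the assay does respond to a change at this part of compound 1, even though the exchanges of ring in compound 2 and compound 3 gave no readable difference, and no measurement at hand bears on why the nitro group has this effect.

With a single substituent at a single place, the compounds shown cannot tell whether the gain belongs to the nitro group itself or would also appear with a nitrile, an amine, a methoxy group or a chlorine atom in the same place. They also leave open whether nitro elsewhere on the phenyl ring would give a similar step, and whether the gain would carry over to the pyridin-2-yl and thiophen-2-yl rings of compound 2 and compound 3.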